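Removing a Trifluoromethyl Group: Cytotoxicity in A549 Cells

A few compounds are considered here, and "the series" means these few. Any claim that something is new, unique, unknown or untested is made for them only; others in the source may bear on it.

Of the compounds shown here, two sharing one core have been measured so far. Compound 1 `Fc1ccc(-n2cc(COc3ccccc3-c3nc4ccccc4s3)nn2)cc1Cl` carries a 3-chloro-4-fluorophenyl group on an aromatic nitrogen, and in a functional assay on A549 cells (Homo sapiens) for cytotoxicity, read by MTT assay, with a stated time of 24 h (on this read-out higher numbers stand for weaker inhibition and lower numbers for stronger inhibition), compound 1 gives 16300 nM. Compound 2 `FC(F)(F)c1cccc(-n2cc(COc3ccccc3-c3nc4ccccc4s3)nn2)c1` carries a 3-(trifluoromethyl)phenyl group at the same place, and in this assay compound 2 gives 11100 nM. The step of a 1.5-fold lower number from compound 1 to compound 2 (0.17 log units; within the scatter) is within the scatter, so the two numbers cannot be told apart; compound 2 stands, on these two numbers, level with compound 1.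

Compound 3 `c1ccc(-n2cc(COc3ccccc3-c3nc4ccccc4s3)nn2)cc1` differs from compound 2 by hydrogen in place of trifluoromethyl on an aromatic carbon. Among the measured compounds shown here, no measured step removes a group outright; the only step on record, a 1.5-fold lower number from compound 1 to compound 2 (0.17 log units; within the scatter), swaps one aryl group for another and leaves the number essentially unchanged. On that evidence no step beyond the scatter in this assay is expected for compound 3 in either direction. The expected step is a 1.3-fold higher number from compound 2 to compound 3 (0.10 log units; within the scatter). For compound 3 the estimate in this assay is 14000 nM, with a likely range from 6000 nM to 35000 nM.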

Compound 3, half-maximal inhibitory concentration: 16400 nM
The estimate for compound 3 lay 1.2-fold (0.07 log units) below the measured number; measured number inside the range.
By their numbers in this assay, from the lowest: compounds 2, 1 and 3 (each within the scatter of the next).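

Among the compounds shown here, until now the only step on record swapped one substituted aryl group for another, whereas this is the first to strip a substituent from the ring, and replacing trifluoromethyl with hydrogen gives a 1.5-fold higher number from compound 2 to compound 3 (0.17 log units; within the scatter) in this assay. The bare phenyl group can also be set against the 3-chloro-4-fluorophenyl group, which gives a 1.0-fold higher number from compound 1 to compound 3 (0.00 log units; within the scatter), so in this assay neither substituted ring can be told apart from the unsubstituted one, and the substituents shown here bring no difference that rises above the noise of the measurement. Nothing at hand explains why this place on the molecule gives such a flat result.

From the compounds shown here alone, whether that flat picture would hold for a different kind of group on this phenyl ring, such as an amine, a carboxylic acid or a longer alkyl chain, remains open. Going by these compounds, all three numbers also come from a single cell line under one set of conditions, so it is equally open whether the same lack of difference would appear in other cells.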